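Swapping a fluoro for a hydroxy on the pendant phenyl

A few compounds are considered here, and "the series" means these few. Any claim that something is new, unique, unknown or untested is made for them only; others in the source may bear on it.

Compound 3 `COc1ccc(S(=O)(=O)N2CCc3cccc(-c4ccc(F)cc4)c32)cc1` gives 86 nM in a functional assay on KB cells (Homo sapiens) for inhibition, with a stated time of 72 h; a higher number here means a weaker inhibitor, a lower number a stronger inhibitor. Compound 1 `COc1ccc(S(=O)(=O)N2CCc3cccc(-c4ccco4)c32)cc1` gives 82 nM, and compound 2 `COc1ccc(S(=O)(=O)N2CCc3cccc(-c4cc(OC)c(OC)c(OC)c4)c32)cc1` gives 3690 nM. Compound 3 thus stands second highest of the three numbers, within the scatter of compound 1 and far below compound 2. The step of a 1.0-fold higher number from compound 1 to compound 3 (0.02 log units; within the scatter) shows that exchanging the whole pendant ring left the number essentially where it was. Compound 4 `COc1ccc(S(=O)(=O)N2CCc3cccc(-c4ccc(O)cc4)c32)cc1` differs from compound 3 by hydroxy in place of fluoro on an aromatic carbon. Among the compounds with values here, no measured step exchanges one substituent on this phenyl, so the only guide is that indifference to the pendant ring, set against the large loss seen for compound 2. A small step of a 1.7-fold higher number from compound 3 to compound 4 (0.24 log units; within the scatter) of uncertain direction is expected. Compound 4 is estimated at 150 nM, within 40 nM to 600 nM.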

Compound 4, half-maximal inhibitory concentration: 129 nM
For compound 4 the middle estimate is 1.2-fold (0.07 log units) above the measured one, within the range that was stated.
By their numbers in this assay, from the lowest: compounds 1, 3 and 4 (each within the scatter of the next); then compound 2.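

Where the earlier step replaced a whole ring, this one exchanges a single group on the phenyl, and a 1.5-fold higher number from compound 3 to compound 4 (0.18 log units; within the scatter) in this assay shows that a hydrogen-bond donor can enter at this place without a change beyond the scatter. The step of a 1.6-fold higher number from compound 1 to compound 4 (0.20 log units; within the scatter) also stays within the scatter, so 4-hydroxyphenyl sits with furan-2-yl and 4-fluorophenyl. Nothing measured here explains this tolerance. Still open, as far as these compounds go, is whether an amine, a carboxylic acid or a longer chain at this place would leave the number similarly unchanged.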